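The source may hold more compounds than are shown below. What is called first, only, known or untested is meant among the compounds shown, and "the series" means these compounds.

Three members of the shared core have numbers in an assay on isolated protein for inhibition of Rho-associated protein kinase 2 (Homo sapiens), read by scintillation counting, radiometric assay and 33P incorporation, with a stated time of 40 min, in the presence of a further agent that is not named here; a higher number here means a weaker inhibitor, a lower number a stronger inhibitor. Compound 1 `CCc1ccc(C(=O)Nc2cccc(NC(=O)COc3ccc4c(=O)ccoc4c3)c2)cc1` gives 24 nM in this assay. Compound 2 `O=C(COc1ccc2c(=O)ccoc2c1)Nc1cccc(NC(=O)c2ccc(Br)cc2)c1` gives 49 nM in this assay. Compound 3 `O=C(COc1ccc2c(=O)ccoc2c1)Nc1cccc(NC(=O)c2ccc(OC(F)(F)F)cc2)c1` gives 77 nM in this assay and stands at the upper end of the three numbers, though its gap to compound 2 lies within the scatter; the steps of a 2.0-fold higher number from compound 1 to compound 2 (0.31 log units; beyond the scatter) and a 3.2-fold higher number from compound 1 to compound 3 (0.51 log units; beyond the scatter) lie beyond it, while a 1.6-fold higher number from compound 2 to compound 3 (0.20 log units; within the scatter) does not.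

Compound 4 `O=C(COc1ccc2c(=O)ccoc2c1)Nc1cccc(NC(=O)c2cnc(C(F)(F)F)s2)c1` differs from compound 3 in one place: 2-(trifluoromethyl)-1,3-thiazol-5-yl in place of 4-(trifluoromethoxy)phenyl on a carbonyl carbon. Among the compounds with values here, none of the measured steps exchanges the ring itself; each only swaps one group on an aromatic carbon for another, and each was modest at most. Within the data shown here, there is no measured step that bears directly on this change. The step in this assay from compound 3 to compound 4 is therefore expected to be small and of uncertain direction, the expected step being a 1.6-fold higher number from compound 3 to compound 4 (0.19 log units; within the scatter). Compound 4 is estimated at 120 nM in this assay, with a range from 35 nM to 400 nM.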

Compound 4, half-maximal inhibitory concentration: 10 nM
Compound 4: middle estimate off by 12-fold (1.08 log units), on the high side; the whole stated range lies above it.
By their numbers in this assay, from the lowest: compound 4; then compound 1; then compounds 2 and 3 (each within the scatter of the next).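

At this carbonyl carbon in this assay, the ring itself can be exchanged with a gain: 2-(trifluoromethyl)-1,3-thiazol-5-yl gives a 7.7-fold lower number from compound 3 to compound 4 (0.89 log units; beyond the scatter) and a 4.9-fold lower number from compound 2 to compound 4 (0.69 log units; beyond the scatter) and also a 2.4-fold lower number from compound 1 to compound 4 (0.38 log units; beyond the scatter) with all three steps beyond the scatter. The earlier compounds shown here varied only the group on an aromatic carbon of a six-membered ring, and compound 4 now stands lower than all of them, including the 4-ethylphenyl of compound 1. Nothing available here accounts for this gain.

As far as these compounds go, the ring and its trifluoromethyl group enter together in compound 4, so their separate shares in the step remain open. Also open, from the compounds shown here alone, is whether the five-membered ring keeps this level with an amine or a methyl group in place of the trifluoromethyl.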